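From chloro to bromo on the shared core

This account rests on a few compounds, and the source may have more. Where it says the series, first, only, none or still open, it means among the compounds named here.

Measured in a functional assay on HeLa cells (Homo sapiens) for antiproliferative activity, read by MTT assay, with a stated time of 48 h; on this read-out higher numbers stand for weaker inhibition and lower numbers for stronger inhibition:
- compound 1 `Fc1ccc(-c2nn(-c3ccccc3)cc2-c2nc3cc(Br)ccc3[nH]2)cc1`: 4940 nM
- compound 2 `Clc1ccc(-c2nn(-c3ccccc3)cc2-c2nc3cc(Br)ccc3[nH]2)cc1`: 2160 nM
- compound 3 `COc1ccc(-c2nn(-c3ccccc3)cc2-c2nc3cc(Cl)ccc3[nH]2)cc1`: 1290 nM

The number for compound 3 lies within the scatter of the number for compound 2, while the gap between compound 3 and compound 1 lies beyond the scatter, with compound 3 the lower of those two. Compound 4 `COc1ccc(-c2nn(-c3ccccc3)cc2-c2nc3cc(Br)ccc3[nH]2)cc1` differs from compound 3 in one place: bromo in place of chloro on an aromatic carbon.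

Going by the values given here, no measured pair makes this exact exchange. The closest evidence is a different halogen exchange at a different carbon, chloro in place of fluoro on an aromatic carbon, which gave a 2.3-fold lower number from compound 1 to compound 2 (0.36 log units; beyond the scatter). That single modest step fixes no direction for the new exchange, so no step beyond the scatter is expected in this assay. The expected change is a 1.0-fold higher number from compound 3 to compound 4 (0.00 log units; within the scatter). Compound 4 is estimated at 1300 nM, with an expected range of 600 nM to 2800 nM.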

Compound 4, half-maximal inhibitory concentration: 1060 nM
Beside the measured number, compound 4's estimate is 1.2-fold (0.09 log units) above it, and the stated range covers the measured number.
By their numbers in this assay, from the lowest: compounds 4, 3 and 2 (each within the scatter of the next, the first and the last beyond it); then compound 1.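

In this assay, the exchange of chloro for bromo on this aromatic carbon of the fused two-ring system gives a 1.2-fold lower number from compound 3 to compound 4 (0.09 log units; within the scatter), so with a methoxy group elsewhere on the molecule, the data do not separate these two halogens at this position. Compound 4 also adds methoxy to the bromo series, where only fluoro and chloro had been compared: methoxy in place of chloro gives a 2.0-fold lower number from compound 2 to compound 4 (0.31 log units; beyond the scatter), and methoxy in place of fluoro gives a 4.7-fold lower number from compound 1 to compound 4 (0.67 log units; beyond the scatter). Among these three bromo compounds, the methoxy compound therefore has the lowest number, with both steps beyond the scatter.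

As far as these compounds go, whether an amine or a carboxylic acid at the halogen-bearing carbon would stay close to these values remains open. No measurement shown accounts for any of these steps.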